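A few compounds are considered here, and "the series" means these few. Any claim that something is new, unique, unknown or untested is made for them only; others in the source may bear on it.

Measured compounds:
- Compound 1, `Cn1c(SCC(=O)N2CCC[C@H]2C(=O)Nc2ccccc2-n2cccc2)nc2ccccc21` — 9 nM
- Compound 2, `Cc1ccc2[nH]c(SCC(=O)N3CCC[C@H]3C(=O)Nc3ccccc3-n3cccc3)nc2c1` — 3 nM
- Compound 3, `O=C(Nc1ccccc1-c1ccccc1)[C@@H]1CCCN1C(=O)CCc1nc2ccccc2[nH]1` — 40 nM

All three were tested in an assay on CHO cells for displacement of a labelled ligand from Orexin/Hypocretin receptor type 1 (Homo sapiens); a lower number here means a stronger inhibitor, a higher number a weaker inhibitor. Among them compound 3 stands highest, that is, it is the weakest of the three: compound 1 gives 9 nM and compound 2 gives 3 nM, both clearly lower than the value of compound 3. Within the data shown here, the one step that can be read within one change is a 3.0-fold lower number from compound 1 to compound 2 (0.48 log units; beyond the scatter), and it concerns the benzimidazole group on the sulfur, not the part of the molecule changed here.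

Compound 4, `O=C(Nc1ccccc1-n1cccc1)[C@@H]1CCCN1C(=O)CCc1nc2ccccc2[nH]1`, is not yet measured. It differs from compound 3 in one place: 1H-pyrrol-1-yl in place of phenyl on an aromatic carbon, on an aromatic carbon of a six-membered aromatic ring of carbon only, ortho to a large group. Among the measured compounds shown here, no measured step isolates this change. Still, the two compounds that carry the 1H-pyrrol-1-yl group, compound 1 and compound 2, give the lower numbers, although they also differ from compound 3 in the linker and in the benzimidazole. On that basis a drop is expected, estimated as a 2.2-fold lower number from compound 3 to compound 4 (0.35 log units; beyond the scatter). Compound 4 is therefore expected to give about 18 nM, within a range of 6 nM to 55 nM.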

Compound 4, inhibition constant: 130 nM
The estimate for compound 4 lay 7.2-fold (0.86 log units) below the measured number; measured number above the stated range.
By their numbers in this assay, from the lowest: compound 2; then compound 1; then compound 3; then compound 4.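

In this assay, with the (1H-benzimidazol-2-yl)methyl group held in place, putting 1H-pyrrol-1-yl in place of phenyl on the aromatic carbon gives a 3.3-fold higher number from compound 3 to compound 4 (0.51 log units; beyond the scatter) and so goes the wrong way: 1H-pyrrol-1-yl alone does not bring the low numbers of compound 1 and compound 2. With 1H-pyrrol-1-yl kept, the much larger steps are a 43-fold higher number from compound 2 to compound 4 (1.64 log units; beyond the scatter) and a 14-fold higher number from compound 1 to compound 4 (1.16 log units; beyond the scatter) on exchanging a benzimidazolyl sulfanyl group for (1H-benzimidazol-2-yl)methyl, so among these compounds the low numbers go with the sulfanyl groups. Nothing measured here explains why phenyl gives the lower number in this pair.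

Still open, as far as these compounds go, is whether phenyl would also give a lower number than 1H-pyrrol-1-yl alongside the sulfanyl groups, and how much of the larger steps belongs to the sulfur and how much to the methyl on the benzimidazole, since these change together. From the compounds shown here alone, how a pyridine ring or a cyclohexyl ring would read on the same aromatic carbon also remains unknown.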